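Fluoro on the phenyl ring in two arrangements of one core

This account rests on a few compounds, and the source may have more. Where it says the series, first, only, none or still open, it means among the compounds named here.

Compound 1 `COc1ccc(-c2cc(C(C)=O)c3[nH]c(-c4ccccc4)cc3c2)cc1` and compound 2 `COc1ccc(-c2cc(C(C)=O)c3[nH]c(-c4ccc(F)cc4)cc3c2)cc1` share one core and differ by fluoro in place of hydrogen on an aromatic carbon. In a functional assay on MCF7 cells (Homo sapiens) for cytotoxicity, read by MTT assay, with a stated time of 2 days, tested at 1 uM (a lower number here means a stronger effect, a higher number a weaker effect of the compound at the concentration tested), compound 1 gives 88.8%, and compound 2 gives 69.7%, a step of a number 19.1 percentage points lower from compound 1 to compound 2 (beyond the scatter). Compound 3 `COc1ccc(-c2cc3cc(-c4ccccc4)cc(C(C)=O)c3[nH]2)cc1` is built from the same atoms as compound 1, joined differently; how the two cores differ is not broken down here. In this assay compound 3 gives 78.1%. Compound 4 `COc1ccc(-c2cc3cc(-c4ccc(F)cc4)cc(C(C)=O)c3[nH]2)cc1` is the partner of compound 3 and differs from it by fluoro in place of hydrogen on an aromatic carbon, the same change seen between compound 1 and compound 2. A step of about the same size is expected, so a number 16.1 percentage points lower from compound 3 to compound 4 (beyond the scatter) is the estimated step from compound 3 to compound 4 in this assay, resting on the measured step of a number 19.1 percentage points lower from compound 1 to compound 2 (beyond the scatter). Compound 4 is therefore expected to give about 62%, most likely between 46% and 78%.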

Compound 4, a percentage reported as activity, at one concentration (the size of the read-out at that concentration, not a potency): 96.4%
Beside the measured number, compound 4's estimate is 34.4 percentage points below it; the whole stated range lies below it.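

In this assay, the change from phenyl to 4-fluorophenyl gives a number 18.3 percentage points higher from compound 3 to compound 4 (beyond the scatter), the opposite direction to the first pair, so the step did not carry over from one core to the other: the same change on two cores in this assay, a number 19.1 percentage points lower (beyond the scatter) from compound 1 to compound 2 and a number 18.3 percentage points higher (beyond the scatter) from compound 3 to compound 4, 37.4 percentage points apart, beyond the scatter of two such steps

The same fluoro goes with a stronger effect on the core of compound 1 and a weaker effect on the core of compound 3, so in these two pairs the outcome depends on the core. This does not show why the direction reverses, and two pairs cannot predict the direction on any further core.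

On these data alone, it remains open whether chloro or an amine in place of that hydrogen would also split between the two cores. As far as these compounds go, it also remains open whether the reversal would persist at other concentrations.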